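A Methoxy Step Seen Twice in A549 Growth Inhibition

The source may report more compounds than this note shows. Statements on the series, on what has been measured and on what is new or still open speak of the compounds shown alone.

Compound 1 `O=C(/C=C/c1ccccc1-c1ccc(F)nc1)c1cccc(O)c1`: in a functional assay on A549 cells (Homo sapiens) for antiproliferative activity, read by sulforhodamine B assay, with a stated time of 48 h (on this read-out lower numbers stand for stronger inhibition and higher numbers for weaker inhibition), compound 1 gives 6900 nM.
Compound 2 `COc1ccc(C(=O)/C=C/c2ccccc2-c2ccc(F)nc2)cc1O`: in this assay compound 2 gives 3200 nM.
Compound 3 `COc1ccc(CNC(=O)c2ccccc2-c2ccc(F)cc2)cc1OC`: in this assay compound 3 gives only a limit of the assay, > 50000 nM.

Compound 1 and compound 2 share one core and differ in a single spot: methoxy in place of hydrogen on an aromatic carbon. That change gives a 2.2-fold lower number from compound 1 to compound 2 (0.33 log units; beyond the scatter). Compound 3 carries a different core; how its core differs from the core of compound 1 is not broken down here. The value of compound 3 is a limit and not a number, and the limit of > 50000 nM in this assay, at which 1 of the 3 values shown sits, tells where that limit lies.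

Compound 4, `COc1cc(CNC(=O)c2ccccc2-c2ccc(F)cc2)cc(OC)c1OC`, has not yet been measured in this assay. It differs from compound 3 in one place: methoxy in place of hydrogen on an aromatic carbon. Within the data shown here, this is the same kind of change as the one from compound 1 to compound 2, though the surroundings differ: in compound 2 the new group sits ortho to a hydroxy group and para to a large group, while in compound 4 it sits ortho to a methoxy group, meta to a large group and meta to a methoxy group.

The step from compound 3 to compound 4 starts from a limit rather than a number, so it cannot be laid beside the earlier step as two measured values. Were it to follow the earlier step, the expected step would be a number no higher from compound 3 to compound 4 (the limit leaves the size open). Compound 4 is expected to give about 50000 nM in this assay, with a likely range from 20000 nM to 150000 nM, and most probably again only a limit.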

Compound 4, half-maximal inhibitory concentration: > 50000 nM
Compound 4 was reported as a limit (the forecaster's own chance of this, stated with the estimate: 70%); the middle value lies on the limit itself.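

No step can be read from compound 3 to compound 4, since in this assay both are reported only as limits of the assay: the limit of > 50000 nM in this assay, at which 2 of the 4 values shown sit.

The compounds shown leave open whether methoxy in place of hydrogen changes growth inhibition at all on the core of compound 3, and so whether this change would match the one seen between compound 1 and compound 2.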